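The compounds below may be only part of what the source reports. "The series", "measured", "known", "first", "only" and "open" are said of these compounds alone.

Measured so far in a physicochemical assay for solubility, with a stated time of 18 h, at pH 7.4; on this read-out lower numbers stand for lower solubility and higher numbers for higher solubility:

compound 1, `COc1ccc(F)cc1CNCCCNc1ccnc2cc(Cc3ccc(F)cc3Cl)ccc12`: 4200 nM
compound 2, `CC(C)CCc1ccc2c(NCCCNCc3ccco3)ccnc2c1`: 4200 nM
compound 3, `Fc1ccc(Cc2ccc3c(NCCCNCc4ccco4)ccnc3c2)c(Cl)c1`: 4200 nM

Compound 1 stands level with compounds 2 and 3 at the digits shown; all three values lie within the usual scatter of one another, so no order among them can be read. Two single-point steps connect the set. From compound 1 to compound 3 the furan-2-yl replaces the 5-fluoro-2-methoxyphenyl on the saturated chain carbon bound to an amine nitrogen, with no change at the digits printed from compound 1 to compound 3 (within the scatter). From compound 2 to compound 3 the 2-chloro-4-fluorophenyl replaces the isobutyl on the saturated chain carbon bound to an aromatic carbon, with no change at the digits printed from compound 2 to compound 3 (within the scatter).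

Compound 4, `COc1ccc(F)cc1CNCCCNc1ccnc2cc(-c3ccc(C(F)(F)F)cc3)ccc12`, is not yet measured. It differs from compound 1 in one place: 4-(trifluoromethyl)phenyl in place of 2-chloro-4-fluorobenzyl on an aromatic carbon. The step from compound 2 to compound 3 is the only one touching the same part of the core, and it exchanged one group for another on a saturated carbon; here the saturated carbon is dropped and an aromatic ring is joined directly to the core. Among the measured compounds shown here, no measured step covers that kind of change, so the expectation for compound 4 in this assay rests on the flat behaviour of the three known values and is held loosely.

Compound 4 is expected to sit near or a little under compound 1, with an estimated step of a 1.4-fold lower number from compound 1 to compound 4 (0.15 log units; within the scatter). The estimate for compound 4 is 3000 nM, with a range from 1000 nM to 6000 nM.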

Compound 4, solubility: 32000 nM
Estimate against measurement, compound 4: 11-fold (1.03 log units) below; measured number above the stated range.
By their numbers in this assay, from the lowest: compounds 1, 2 and 3 (each within the scatter of the next); then compound 4.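

In this assay, the aromatic carbon of the shared core that is meta to a fused ring and para to a fused ring now proves able to move the read-out: 4-(trifluoromethyl)phenyl in place of 2-chloro-4-fluorobenzyl gives a 7.6-fold higher number from compound 1 to compound 4 (0.88 log units; beyond the scatter) on the side chain of compound 1. The earlier exchange in this part of the core, made on a saturated chain carbon, gave no change at the digits printed from compound 2 to compound 3 (within the scatter) and offered no sign that this read-out could respond to a change here. Nothing measured in the compounds shown accounts for the new step.

The step combines two differences, the loss of the saturated carbon joining the ring to the core and the exchange of the ring's chlorine and fluorine for trifluoromethyl, and the compounds shown do not separate them; a directly joined 2-chloro-4-fluorophenyl or a 4-(trifluoromethyl)benzyl group would do so. Going by these compounds, it also remains open whether the same step would appear with the furan-2-yl side chain of compound 3, or whether a saturated amine such as morpholine at this carbon would behave in the same way.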